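This account rests on a few compounds, and the source may have more. Where it says the series, first, only, none or still open, it means among the compounds named here.

Measured compounds:
compound 1 `Nc1cc(N)c2nc(-c3ccccc3)c(Oc3ccc(Cl)c(Cl)c3)nc2c1` — 58900 nM
compound 2 `Nc1cc(N)c2nc(-c3ccccc3)c(NCc3ccc(Cl)c(Cl)c3)nc2c1` — 40700 nM
compound 3 `COc1cc(CNc2nc3cc(N)cc(N)c3nc2-c2ccccc2)cc(OC)c1OC` — < 50200 nM

Going by the values given here, in a functional assay on OVCAR-5 cells (Homo sapiens) for inhibition, read by sulforhodamine B assay, with a stated time of 48 h (a lower number here means a stronger inhibitor of growth, a higher number a weaker inhibitor of growth), compound 1 gives 58900 nM, the higher of the two numbers known. Compound 2 gives 40700 nM in this assay, a gap to compound 1 that sits within the usual scatter, so the two compounds are not distinguishable here. For compound 3 the entry of < 50200 nM in this assay is a limit of the assay and not a number (the limit of < 50200 nM in this assay, at which 1 of the 3 values shown sits).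

Compound 4 `Nc1cc(N)c2nc(-c3ccccc3)c(Sc3ccc(Cl)c(Cl)c3)nc2c1` is the next compound to be run in this assay. Relative to compound 1 the change is (3,4-dichlorophenyl)sulfanyl in place of 3,4-dichlorophenoxy on an aromatic carbon. Both groups carry the same count of heavy atoms, the same single aromatic ring and the same donor and acceptor count; the step between compounds 1 and 2 shows the shared core tolerating a change of the linking atom without a shift beyond the scatter. The step of a 1.2-fold lower number from compound 1 to compound 4 (0.07 log units; within the scatter) in this assay is therefore expected to be small, with no direction beyond the scatter. Compound 4 is estimated at 50000 nM in this assay, within 20000 nM to 120000 nM.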

Compound 4, concentration for total growth inhibition: 58900 nM
Compound 4: middle estimate off by 1.2-fold (0.07 log units), on the low side; low and high end bracket the measured number.
By their numbers in this assay, from the lowest: compounds 2, 1 and 4 (each within the scatter of the next).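

In this assay, (3,4-dichlorophenyl)sulfanyl in place of 3,4-dichlorophenoxy, on the aromatic carbon next to the ring nitrogen, gives no change at the digits printed from compound 1 to compound 4 (within the scatter). Going by these compounds alone, this is the first comparison that differs in one place only, and it shows that this position accepts sulfur for oxygen as the linking atom without a readable shift in total growth inhibition. Nothing measured here bears on why the exchange leaves the number in place.

Within the data shown here, only this one exchange at the position can be read, so it remains unknown how far the position tolerates larger departures. On these data alone, whether a carbonyl or a longer chain as the linker, or an amine or a carboxylic acid in place of the chlorine atoms, would move the number beyond the scatter stays open.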